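The source may report more compounds than this note shows. Statements on the series, on what has been measured and on what is new or still open speak of the compounds shown alone.

Measured compounds, all in a functional assay on MCF7 cells (Homo sapiens) for cytotoxicity, read by MTT assay, with a stated time of 72 h; a higher number here means a weaker inhibitor, a lower number a stronger inhibitor:
compound 1 `COc1ccc(/C=C/C(=O)Nc2cc3c(Nc4ccc(F)c(Cl)c4)ncnc3cc2O[C@H]2CCOC2)c(OC)c1OC`, compound 1 gives 4650 nM
compound 2 `O=C(/C=C/c1ccc(Br)cc1)Nc1cc2c(Nc3ccc(F)c(Cl)c3)ncnc2cc1O[C@H]1CCOC1`, compound 2 gives 32400 nM
compound 3 `O=C(/C=C/c1cc(Br)c(O)c(Br)c1)Nc1cc2c(Nc3ccc(F)c(Cl)c3)ncnc2cc1O[C@H]1CCOC1`, compound 3 gives 30600 nM

Compound 3 stands second highest of the three numbers. Its nearest neighbour is compound 2, a 1.1-fold lower number from compound 2 to compound 3 (0.02 log units; within the scatter), so the two are indistinguishable on this read-out. Within the data shown here, the only clearly separated compound is compound 1: a 6.6-fold higher number from compound 1 to compound 3 (0.82 log units; beyond the scatter), and likewise a 7.0-fold higher number from compound 1 to compound 2 (0.84 log units; beyond the scatter).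

The next compound, compound 4 `O=C(/C=C/c1ccccc1[N+](=O)[O-])Nc1cc2c(Nc3ccc(F)c(Cl)c3)ncnc2cc1O[C@H]1CCOC1`, is not yet measured. It differs from compound 3 in one place: 2-nitrophenyl in place of 3,5-dibromo-4-hydroxyphenyl on a double-bonded chain carbon bound to a double-bonded chain carbon.

Bearing on this change are the steps already seen. The swap of one substituted phenyl for another on the chain carbon, a 1.1-fold lower number from compound 2 to compound 3 (0.02 log units; within the scatter), left the number unchanged within the scatter. Only the trimethoxyphenyl of compound 1 gave a lower number, and that group is not involved here. Among the measured compounds shown here, the nitrophenyl has no measured precedent, so the direction cannot be fixed from the data; the expectation is a step within the scatter, a 1.2-fold lower number from compound 3 to compound 4 (0.09 log units; within the scatter), or at most a modest move in either direction.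

Compound 4 is therefore estimated at 25000 nM in this assay, with a range from 8000 nM to 60000 nM.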

Compound 4, half-maximal inhibitory concentration: 28400 nM
Estimate against measurement, compound 4: 1.1-fold (0.06 log units) below; the range from low to high includes it.
By their numbers in this assay, from the lowest: compound 1; then compounds 4, 3 and 2 (each within the scatter of the next).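

In this assay the 2-nitrophenyl on a double-bonded chain carbon bound to a double-bonded chain carbon gives a 1.1-fold lower number from compound 3 to compound 4 (0.03 log units; within the scatter) and a 1.1-fold lower number from compound 2 to compound 4 (0.06 log units; within the scatter), so a phenyl group carrying no bromine and no hydroxyl sits with the two brominated ones on this read-out. Three differently substituted phenyl groups now fall within the scatter of one another, and the 2,3,4-trimethoxyphenyl of compound 1 goes against this grouping, with a 6.1-fold higher number from compound 1 to compound 4 (0.79 log units; beyond the scatter) as a further step beyond the scatter from it. Nothing available explains either the flat stretch across compounds 2, 3 and 4 or the separation of compound 1.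

Still open, as far as these compounds go, is whether the separation of compound 1 needs all three methoxy groups, as a single methoxyphenyl or a 3,4,5-trimethoxyphenyl at this place would show, and whether an unsubstituted phenyl would join the flat stretch. Also open, from the compounds shown here alone, is how far the number would move with no aromatic ring at this place at all, for example with a dimethylamine or a carboxylic acid on the chain.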